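Swapping a methyl for two chlorines on the amide aryl

The compounds below may be only part of what the source reports. "The series", "measured", "known", "first", "only" and "open" are said of these compounds alone.

Three amides built on a shared core have been tested in an assay on LtK cells with ATP-sensitive inward rectifier potassium channel 11 (Homo sapiens) as the target; a higher number here means that more compound is needed for the effect, a lower number that less compound is needed. Compound 1 `CCC(CC)C(=O)Nc1c(C(O)(C(F)(F)F)C(F)(F)F)ccc2ccccc12` gives 4340 nM. Compound 2 `O=C(Nc1c(C(O)(C(F)(F)F)C(F)(F)F)ccc2ccccc12)c1ccccc1Cl` gives 2040 nM, the step of a 2.1-fold lower number from compound 1 to compound 2 (0.33 log units; beyond the scatter) being modest but beyond the scatter. Compound 3 `Cc1ccccc1C(=O)Nc1c(C(O)(C(F)(F)F)C(F)(F)F)ccc2ccccc12` gives 5550 nM, the highest of the three numbers: its step of a 1.3-fold higher number from compound 1 to compound 3 (0.11 log units; within the scatter) lies within the scatter, while a 2.7-fold higher number from compound 2 to compound 3 (0.43 log units; beyond the scatter) lies beyond it.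

Compound 4 `O=C(Nc1c(C(O)(C(F)(F)F)C(F)(F)F)ccc2ccccc12)c1cccc(Cl)c1Cl` differs from compound 3 in one place: 2,3-dichlorophenyl in place of 2-methylphenyl on a carbonyl carbon. Among the compounds with values here, the measured step that bears on this is a 2.7-fold higher number from compound 2 to compound 3 (0.43 log units; beyond the scatter), which in reverse reads methyl giving way to chloro with a lower number; compound 4 carries that chloro and a second one in addition, for which no measured step exists. Compound 4 is therefore expected to show a step of a 3.7-fold lower number from compound 3 to compound 4 (0.57 log units; beyond the scatter), downward and beyond the scatter. The estimate for compound 4 in this assay is 1500 nM, within a range from 600 nM to 4000 nM.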

Compound 4, half-maximal effective concentration: > 10000 nM
Compound 4: a limit, no number; the forecaster's own chance of this, stated with the estimate: 3%; middle value at least 6.6-fold (0.82 log units) from the limit.
By their numbers in this assay, from the lowest: compound 2; then compounds 1 and 3 (each within the scatter of the next). At a limit, above all of these: compound 4.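

In this assay compound 4 stands at a limit and not at a number: the limit of > 10000 nM in this assay, at which 1 of the 4 values shown sits. Within the data shown here, the second chloro turns the direction around, with an at least 4.9-fold higher number from compound 2 to compound 4 (0.69 log units; beyond the scatter), so the lower number that came with the single chloro of compound 2 did not carry over to the 2,3-dichlorophenyl amide. The other two steps are floors, an at least 2.3-fold higher number from compound 1 to compound 4 (0.36 log units; beyond the scatter) clearing the scatter against the pentan-3-yl amide, while an at least 1.8-fold higher number from compound 3 to compound 4 (0.25 log units; that floor lies within the scatter) has a floor that stays within it.

As far as these compounds go, how far beyond its limit compound 4 lies remains unknown. Also open, from the compounds shown here alone, is whether a fluoro, a methoxy or a nitrile in place of the second chloro on the same aryl would raise the number as well, or whether this rise is peculiar to chloro.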